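The source may report more compounds than this note shows. Statements on the series, on what has been measured and on what is new or still open speak of the compounds shown alone.

In a physicochemical assay for lipophilicity, read by HPLC, at pH 7.4 (on this read-out higher numbers stand for higher lipophilicity and lower numbers for lower lipophilicity), compound 2 `O=C(O)Cc1ccc(-c2ccc(CN3CC(=O)N(C4CCCCC4)C3=O)nc2)cc1` gives -0.35, the lowest of the three numbers measured. The nearest of the other two is compound 1 `O=C(O)Cc1ccc(-c2ccc(CN3CC(=O)N(c4ccccc4)C3=O)cc2)cc1`, which in this assay gives 2.18, a number that stands beyond the scatter above that of compound 2. The furthest is compound 3 `O=C(Nc1cccc(-c2ccccc2)c1)OCc1ccccc1`, which in this assay gives 7.52, again beyond the scatter away from compound 2. Compound 4 `CC(C)N1C(=O)CN(Cc2ccc(-c3ccc(CC(=O)O)cc3)cn2)C1=O` has not yet been measured in this assay. It differs from compound 2 in one place: isopropyl in place of cyclohexyl on an amide-type nitrogen in a ring. No pair of measured compounds that differ in only one place is available, so the size of such a step cannot be read from the numbers shown. Compound 4 is nonetheless expected to sit lower in this assay than compound 2, by an estimated step of a number 0.95 log units lower from compound 2 to compound 4 (beyond the scatter), which would lie beyond the scatter. The value expected for compound 4 in this assay is -1.3, with a range from -2.1 to -0.5.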

Compound 4, distribution coefficient: -1.38
Compound 4: middle estimate off by 0.08 log units, on the high side; the range from low to high includes it.
By their numbers in this assay, from the lowest: compound 4; then compound 2; then compound 1; then compound 3.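

Isopropyl in place of cyclohexyl on an amide-type nitrogen in a ring gives a number 1.03 log units lower from compound 2 to compound 4 (beyond the scatter) in this assay and is the first single-place step that can be read for this position. The change removes the six-membered non-aromatic ring of carbon only and replaces a group of 6 heavy atoms with one of 3, while neither group has hydrogen-bond donors, hydrogen-bond acceptors or a net charge, so a swap between two all-carbon groups at this nitrogen is enough to give a step beyond the scatter. No measurement shown accounts for the size of this step.

Still open, on these data alone, is what a methyl group, a straight butyl chain or a chain ending in an amine would give at this nitrogen. As far as these compounds go, it is also open whether the same change would give a similar step on a core other than that of compound 2.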